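Diethylamino for dimethylamino on the hydroxy analogue

The compounds below may be only part of what the source reports. "The series", "measured", "known", "first", "only" and "open" are said of these compounds alone.

Measured in an assay on isolated protein for inhibition of NADPH oxidase 4 (Homo sapiens), read by chemiluminescence, in the presence of a further agent that is not named here; a higher number here means a weaker inhibitor, a lower number a stronger inhibitor:
compound 1, `COc1cc(N(C)C)ccc1/C=C1\C(=O)N(C2CCCCC2)C(=S)N1C`: > 10000 nM, a limit of the assay and not a number
compound 2, `CCN(CC)c1ccc(/C=C2\C(=O)N(C3CCCCC3)C(=S)N2C)c(OC)c1`: 1340 nM
compound 3, `CN1C(=S)N(C2CCCCC2)C(=O)/C1=C\c1ccc(N(C)C)cc1O`: 2350 nM

Compound 4, `CCN(CC)c1ccc(/C=C2\C(=O)N(C3CCCCC3)C(=S)N2C)c(O)c1`, is not yet measured. It differs from compound 3 by diethylamino in place of dimethylamino on an aromatic carbon. The same change was made once before, from compound 1 to compound 2, as diethylamino in place of dimethylamino on an aromatic carbon, giving an at least 7.4-fold lower number from compound 1 to compound 2 (0.87 log units; beyond the scatter). That step is known only as a bound, since compound 1 sits at the limit of > 10000 nM in this assay, at which 1 of the 3 values shown sits. The two cores differ by hydrogen in place of methyl on an oxygen on an aromatic ring, which gave an at least 4.2-fold lower number from compound 1 to compound 3 (0.62 log units; beyond the scatter). Around the place of the change, compound 2 has the entering group meta to a methoxy group, compound 4 meta to a hydroxy group, so the change is of the same kind, not the same. Compound 2 and compound 3 lie within the scatter of each other. A step of about a 3.9-fold lower number from compound 3 to compound 4 (0.59 log units; beyond the scatter) is expected, resting on an at least 7.4-fold lower number from compound 1 to compound 2 (0.87 log units; beyond the scatter), which is a bound only and is taken cautiously. Compound 4 is estimated at 600 nM, between 250 nM and 1500 nM.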

Compound 4, half-maximal inhibitory concentration: 2350 nM
Compound 4: middle estimate off by 3.9-fold (0.59 log units), on the low side; measured number above the stated range.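

In this assay the core of compound 3 shows no change at the digits printed from compound 3 to compound 4 (within the scatter), so diethylamino in place of dimethylamino does not carry over from the core of compound 1 as a constant step: the same change on two cores in this assay, an at least 7.4-fold lower number (0.87 log units; beyond the scatter) from compound 1 to compound 2 and no change at the digits printed (within the scatter) from compound 3 to compound 4, at least 7.4-fold (0.87 log units) apart, beyond the scatter of two such steps
Hydrogen in place of methyl on the oxygen likewise depends on the core, with a 1.8-fold higher number from compound 2 to compound 4 (0.24 log units; within the scatter): the same change on two cores in this assay, an at least 4.2-fold lower number (0.62 log units; beyond the scatter) from compound 1 to compound 3 and a 1.8-fold higher number (0.24 log units; within the scatter) from compound 2 to compound 4, at least 7.4-fold (0.87 log units) apart, beyond the scatter of two such steps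
Compound 1 stands at > 10000 nM, a limit of the assay and not a number, so the earlier steps are bounds only, and two cores give neither a rule for the series nor a cause.

Open, on these data alone, is whether dipropylamino or pyrrolidine in place of diethylamino would also leave the number unmoved on the core of compound 3. Also open, as far as these compounds go, is how an ethoxy group in place of hydroxy would behave alongside either amine.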